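The compounds below may be only part of what the source reports. "The series", "measured", "known", "first", "only" and "open" are said of these compounds alone.

Compound 1 `Cc1nc(C2CC2)cc2nn(-c3ccccc3)cc12` sits at the top of the two numbers in a functional assay on MCF7 cells (Homo sapiens) for inhibition, read by fluorescence, with a stated time of 72 h; a lower number here means a stronger inhibitor of growth, a higher number a weaker inhibitor of growth: compound 1 gives 63500 nM, whereas compound 2 `CCCCc1cc2nn(-c3ccccc3)cc2cn1` gives 13300 nM, a gap beyond the usual scatter. Compound 3 `Cn1cc2cnc(-c3ccccc3)cc2n1` reaches only a limit in this assay, recorded as > 100000 nM. The step to compound 4 `Cc1nc(-c2ccsc2)cc2nn(-c3ccccc3)cc12` is thiophen-3-yl in place of cyclopropyl on an aromatic carbon. Among the compounds with values here, no measured pair shows this change, so its size is open, and an expectation for compound 4 rests on compound 1 at 63500 nM alone, with no ground to expect a shift in either direction. The step expected here, a 1.3-fold lower number from compound 1 to compound 4 (0.10 log units; within the scatter), is none beyond the scatter. Compound 4 is therefore estimated at 50000 nM, within a range from 15000 nM to 150000 nM.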

Compound 4, concentration for 50% growth inhibition: 22200 nM
The estimate for compound 4 lay 2.3-fold (0.35 log units) above the measured number; low and high end bracket the measured number.
By their numbers in this assay, from the lowest: compounds 2 and 4 (each within the scatter of the next); then compound 1. At a limit, above all of these: compound 3.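

At this aromatic carbon next to the ring nitrogen, the change to thiophen-3-yl in place of cyclopropyl gives a 2.9-fold lower number from compound 1 to compound 4 (0.46 log units; beyond the scatter) in this assay, so this position responds to its substituent, and an aromatic ring is accepted there with a modest gain. The step stands as one pair only, and nothing at hand bears on its cause. Open, as far as these compounds go, is whether an amine, a carboxylic acid or a phenyl group on this carbon would move the number further, and whether the methyl group contributes at all.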